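The source may report more compounds than this note shows. Statements on the series, on what has been measured and on what is new or still open speak of the compounds shown alone.

Measured in a functional assay on the whole organism (artery, strain albino) with Rattus norvegicus as the target, with a stated time of 60 min, at a dose of 10 mg/kg by the oral route; a higher number here means more inhibition at the dose given (going by the name of the read-out), a lower number less inhibition:
compound 1 `COc1ccc(C2N=C(SCc3ccccc3)NC(C)=C2C(=O)Nc2ccc(Br)cc2)cc1` gives 5.6%
compound 2 `CC1=C(C(=O)Nc2ccc([N+](=O)[O-])cc2)C(c2ccc(Br)cc2)N=C(SCc2ccccc2)N1` gives 8.2%
compound 3 `CC1=C(C(=O)Nc2ccc([N+](=O)[O-])cc2)C(c2cccc([N+](=O)[O-])c2)N=C(SCc2ccccc2)N1` gives 7.7%

Compound 3 stands second highest of these three numbers, yet its gap to compound 2 and its gap to compound 1 both lie within the scatter, so the three compounds cannot be told apart. Going by the values given here, the only measured step, a number 0.5 percentage points lower from compound 2 to compound 3 (within the scatter), concerns a different part of the molecule and also stays within the scatter. Compound 4 `CC1=C(C(=O)Nc2ccc([N+](=O)[O-])cc2)C(c2cccc([N+](=O)[O-])c2)N=C(SCc2ccc(Cl)cc2)N1` differs from compound 3 by chloro in place of hydrogen on an aromatic carbon. Among the compounds with values here, no measured step bears on this change, and nothing in the three values suggests a step beyond the scatter, so compound 4 is expected to give about 8%, in the range 1% to 16%, a step of a number 0.3 percentage points higher from compound 3 to compound 4 (within the scatter).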

Compound 4, a percentage reported as inhibition, in the whole organism at one dose (the size of the read-out at that dose, not a potency): 6.7%
The estimate for compound 4 lay 1.3 percentage points above the measured number; the range from low to high includes it.
By their numbers in this assay, from the lowest: compounds 1, 4, 3 and 2 (each within the scatter of the next).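

In this assay the change from benzylsulfanyl to (4-chlorobenzyl)sulfanyl brings a number 1 percentage points lower from compound 3 to compound 4 (within the scatter) and so gives no readable effect at this position. Going by these compounds alone, this is the first look at the benzylsulfanyl part of the molecule, and like the change on the saturated ring carbon, it shows no step beyond the scatter. No measurement on hand offers an explanation for this result. The compounds shown leave open whether an amine or a carboxylic acid on this phenyl ring, or a longer chain in place of benzyl, would move the inhibition beyond the scatter.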